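A few compounds are considered here, and "the series" means these few. Any claim that something is new, unique, unknown or untested is made for them only; others in the source may bear on it.

Compound 1 `COc1ccc(-c2nc3ccc(-c4nc5cc(C(=N)N)ccc5[nH]4)cc3[nH]2)cc1OC` gives > 90 ug/mL as a limit of the assay.
Compound 2 `N=C(N)c1ccc2[nH]c(-c3ccc4nc(-c5ccc(OCc6ccccc6)cc5)[nH]c4c3)nc2c1` gives 17.4 ug/mL as a measured number.
Compound 3 `COc1cc(-c2nc3ccc(-c4nc5cc(C(=N)N)ccc5[nH]4)cc3[nH]2)ccc1OCc1ccccc1` gives 19.8 ug/mL as a measured number.

In an ADME assay on L6 cells (Rattus norvegicus) for cytotoxicity, read by resazurin assay (a lower number here means a stronger inhibitor, a higher number a weaker inhibitor), compound 3 stands level with compound 2, as the step of a 1.1-fold higher number from compound 2 to compound 3 (0.06 log units; within the scatter) shows, while compound 1 is known only as a limit. Compound 4 `N=C(N)c1ccc2[nH]c(-c3ccc4nc(-c5ccc(OCc6ccccc6)c(OCc6ccccc6)c5)[nH]c4c3)nc2c1` carries one further change, phenyl in place of hydrogen on a saturated chain carbon bound to an oxygen on an aromatic ring and so turns methoxy to benzyloxy. The same change has been seen once, in the step of an at least 4.5-fold lower number from compound 1 to compound 3 (0.65 log units; beyond the scatter) which starts from a limit, so its true size is open. The step of a 1.1-fold higher number from compound 2 to compound 3 (0.06 log units; within the scatter) adds methoxy in place of hydrogen on an aromatic carbon and bears only indirectly. On this single precedent from compound 1 to compound 3, a move towards a lower number is expected, probably of modest size. The estimated step is a 2.8-fold lower number from compound 3 to compound 4 (0.45 log units; beyond the scatter) and it remains an expectation. In this assay compound 4 is expected at 7 ug/mL (estimated range 2.5 ug/mL to 20 ug/mL).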

Compound 4, half-maximal inhibitory concentration: > 90 ug/mL
Compound 4: a limit, no number (the forecaster's own chance of this, stated with the estimate: 3%); at least 12-fold (1.10 log units) between middle value and limit.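

In this assay the change from methoxy to benzyloxy now has two readings that point in opposite directions: an at least 4.5-fold lower number from compound 1 to compound 3 (0.65 log units; beyond the scatter) against an at least 4.5-fold higher number from compound 3 to compound 4 (0.65 log units; beyond the scatter). The change therefore has no single direction in this series, since its outcome differs with what the ring already carries, and adding benzyloxy to the ring of compound 2 gives an at least 5.1-fold higher number from compound 2 to compound 4 (0.71 log units; beyond the scatter). Compound 4 is known only as a limit, so the true size of these steps remains open: the limit of > 90 ug/mL in this assay, at which 2 of the 4 values shown sit.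

The compounds shown do not separate the second benzyloxy itself from the pair of groups taken together. Nor do they show how an amine, a carboxylic acid or a longer chain ending in phenyl would read in place of that benzyloxy.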